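From 2,4-dichlorophenyl to 4-hydroxyphenyl: estimating compound 4

The source may hold more compounds than are shown below. What is called first, only, known or untested is meant among the compounds shown, and "the series" means these compounds.

Of the compounds shown here, three sharing one core have been measured in a functional assay on MCF7 cells (Homo sapiens) for antiproliferative activity, read by MTT assay, with a stated time of 72 h; a higher number here means a weaker inhibitor, a lower number a stronger inhibitor. Compound 1 `COc1cc(-n2cnc3ccc(-c4ccc(C)cc4F)cc32)cc(OC)c1OC` gives 56 nM, compound 2 `COc1cc(-n2cnc3ccc(-c4cccc(Cl)c4)cc32)cc(OC)c1OC` gives 3120 nM, and compound 3 `COc1cc(-n2cnc3ccc(-c4ccc(Cl)cc4Cl)cc32)cc(OC)c1OC` gives 5420 nM. Compound 3 has the highest number of the three, which places it at the weak end of this small set. Its nearest neighbour lies close, with a 1.7-fold higher number from compound 2 to compound 3 (0.24 log units; within the scatter), whereas the distance to the strongest compound is far greater, with a 97-fold higher number from compound 1 to compound 3 (1.99 log units; beyond the scatter).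

Compound 4 `COc1cc(-n2cnc3ccc(-c4ccc(O)cc4)cc32)cc(OC)c1OC` has 4-hydroxyphenyl in place of 2,4-dichlorophenyl on an aromatic carbon. For the measured compounds named here, no measured compound carries this group, so the evidence is indirect. Changing this same group has produced large steps, namely a 56-fold higher number from compound 1 to compound 2 (1.75 log units; beyond the scatter) and a 97-fold higher number from compound 1 to compound 3 (1.99 log units; beyond the scatter), but it has also produced the small step between the two chlorinated compounds. A moderate move toward a lower number is therefore expected in this assay, with real uncertainty. The estimated change is a 4.5-fold lower number from compound 3 to compound 4 (0.65 log units; beyond the scatter). For compound 4 the expected value is 1200 nM, with an estimated range of 150 nM to 8000 nM.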

Compound 4, half-maximal inhibitory concentration: 4160 nM
Compound 4: middle estimate off by 3.5-fold (0.54 log units), on the low side; low and high end bracket the measured number.
By their numbers in this assay, from the lowest: compound 1; then compounds 2, 4 and 3 (each within the scatter of the next).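

In this assay, 4-hydroxyphenyl, with its hydrogen-bond donor and acceptor, behaves at this position much like the chlorinated groups: replacing 2,4-dichlorophenyl gives a 1.3-fold lower number from compound 3 to compound 4 (0.11 log units; within the scatter), and replacing 3-chlorophenyl gives a 1.3-fold higher number from compound 2 to compound 4 (0.12 log units; within the scatter). Removing chlorine from this ring is therefore not enough to reach the potency of the 2-fluoro-4-methylphenyl compound, as a 74-fold higher number from compound 1 to compound 4 (1.87 log units; beyond the scatter) shows, and compound 1 remains clearly the strongest of the four. Nothing measured here explains why these three different groups give such similar results.

The compounds shown leave open whether the fluorine, the methyl or the two together set compound 1 apart. A 4-methylphenyl or a 2-fluorophenyl group at this position would help to separate those possibilities.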